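Chloropropyl for Chloroacetylamino: Compound 4 Foreseen

This account rests on a few compounds, and the source may have more. Where it says the series, first, only, none or still open, it means among the compounds named here.

Measured compounds in a functional assay on MCF7 cells (Homo sapiens) for antiproliferative activity, with a stated time of 48 h; a lower number here means a stronger inhibitor, a higher number a weaker inhibitor:
compound 1 `CC(C)(C)c1ccc(CNC(=O)NC(=O)CCl)cc1` gives 2800 nM
compound 2 `CCCCCc1cccc(NC(=O)NC(=O)CCl)c1` gives 8300 nM
compound 3 `CC(C)(C)c1ccc(CNC(=O)CCCCl)cc1` gives 92000 nM

Compound 3 arises from compound 1 by one change, (3-chloropropyl in place of ((chloromethyl)carbonyl)amino on a carbonyl carbon), and the measured step was a 33-fold higher number from compound 1 to compound 3 (1.52 log units; beyond the scatter). Compound 4 `CCCCCc1cccc(NC(=O)CCCCl)c1` has not yet been measured; it arises from compound 2 by the same change, (3-chloropropyl in place of ((chloromethyl)carbonyl)amino on a carbonyl carbon), at the same kind of place on both cores. The two cores themselves, those of compound 1 and compound 2, are built from the same atoms joined differently, and the difference between the two cores is not broken down here. Compound 2 stands above compound 1 and below compound 3 in this assay, both gaps beyond the scatter.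

On these data alone, since the change appears only once among the measured compounds, its effect on the core of compound 2 is unknown. Still, the step from compound 2 to compound 4 in this assay is expected to be large, a 24-fold higher number from compound 2 to compound 4 (1.38 log units; beyond the scatter), because the same change gave a 33-fold higher number from compound 1 to compound 3 (1.52 log units; beyond the scatter). Compound 4 is therefore estimated at 200000 nM, between 50000 nM and 800000 nM.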

Compound 4, half-maximal inhibitory concentration: > 100000 nM
Compound 4 was reported as a limit (the forecaster's own chance of this, stated with the estimate: 40%); the middle value is on the limit's open side.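

In this assay compound 4 is reported only as a limit of the assay, > 100000 nM. Even so, putting 3-chloropropyl in place of ((chloromethyl)carbonyl)amino on a carbonyl carbon gave an at least 12-fold higher number from compound 2 to compound 4 (1.08 log units; beyond the scatter), so on the core of compound 2 the change again produced a large loss of activity, as it had on the core of compound 1. This shows that the direction of the change and its large size carried over between these two cores, but it does not show that the size was the same on both: the same change on two cores in this assay, a 33-fold higher number (1.52 log units; beyond the scatter) from compound 1 to compound 3 and an at least 12-fold higher number (1.08 log units; beyond the scatter) from compound 2 to compound 4; the limit leaves it open whether they differ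

The compounds shown leave open what a chain without chlorine, a longer chain ending in chlorine, an amine or a carboxylic acid would do in place of ((chloromethyl)carbonyl)amino on either core. They also leave open how far the change would carry to any core beyond these two, since the comparison rests on a single pair of steps.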